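Chain shortening from compound 3 to compound 4

The source may hold more compounds than are shown below. What is called first, only, known or untested is meant among the compounds shown, and "the series" means these compounds.

In a functional assay on CNE-2 cells (Homo sapiens) for inhibition, read by MTT assay, with a stated time of 72 h (on this read-out lower numbers stand for stronger inhibition and higher numbers for weaker inhibition), compound 3 (`Nc1ncnc2c1c(-c1cnc3[nH]ccc3c1)nn2CCCCCCCCCC(=O)NO`) gives 2200 nM and compound 1 (`Nc1ncnc2c1c(-c1cnc3[nH]ccc3c1)nn2CCCCCCCCC(=O)NO`) gives 2270 nM as the two lowest numbers of the series, within the scatter of each other (a 1.0-fold lower number from compound 1 to compound 3 (0.01 log units; within the scatter)). Compound 2 (`Nc1ncnc2c1c(-c1cnc3[nH]ccc3c1)nn2CCCCC(=O)NO`) reads > 150000 nM as a limit of the assay and not as a number.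

Compound 4 (`Nc1ncnc2c1c(-c1cnc3[nH]ccc3c1)nn2CCCC(=O)NO`) differs from compound 3 by a single change (hydroxycarbamoyl in place of 6-(hydroxycarbamoyl)hexyl on a saturated chain carbon, three bonds along the chain from an aromatic nitrogen): hydroxycarbamoyl in place of 6-(hydroxycarbamoyl)hexyl on a saturated chain carbon, three bonds along the chain from an aromatic nitrogen. Its chain is also shorter than that of compound 2.

The closest guides are two large steps, both resting on the limit of compound 2 (an at least 66-fold higher number from compound 1 to compound 2 (1.82 log units; beyond the scatter); an at least 68-fold lower number from compound 2 to compound 3 (1.83 log units; beyond the scatter)). A large step towards a higher number is therefore expected in this assay, and the estimated change is a 91-fold higher number from compound 3 to compound 4 (1.96 log units; beyond the scatter) as weaker inhibition. Compound 4 is estimated at 200000 nM with an expected range from 60000 nM to 600000 nM and may well report only a limit.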

Compound 4, half-maximal inhibitory concentration: > 150000 nM
Compound 4: only a limit was reported; the forecaster's own chance of this, stated with the estimate: 75%; the middle value is on the limit's open side.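

In this assay, the shorter chain again costs a large step, with hydroxycarbamoyl in place of 6-(hydroxycarbamoyl)hexyl giving an at least 68-fold higher number from compound 3 to compound 4 (1.83 log units; beyond the scatter) and hydroxycarbamoyl in place of 5-(hydroxycarbamoyl)pentyl giving an at least 66-fold higher number from compound 1 to compound 4 (1.82 log units; beyond the scatter). Compound 4 reports > 150000 nM, which is a limit and not a number, and its step to compound 2 cannot be read: the limit of > 150000 nM in this assay, at which 2 of the 4 values shown sit. The change that lengthens the chain can now be read in two pairs, not only one: the same change on two cores in this assay, an at least 68-fold lower number (1.83 log units; beyond the scatter) from compound 2 to compound 3 and an at least 66-fold lower number (1.82 log units; beyond the scatter) from compound 4 to compound 1; the limit leaves it open whether they differ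

The compounds shown leave open at which chain length between those of compound 2 and compound 1 the numbers change. Also open, from the compounds shown here alone, is whether a longer chain than that of compound 3, or a carboxylic acid or an amine in place of the hydroxycarbamoyl end on the chain, keeps the number of compound 3.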